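This account rests on a few compounds, and the source may have more. Where it says the series, first, only, none or still open, it means among the compounds named here.

In a functional assay on DU-145 cells (Homo sapiens) for cytotoxicity, read by MTT assay (on this read-out higher numbers stand for weaker inhibition and lower numbers for stronger inhibition), compound 3 `CC(=O)OC(C)CO[C@H](CC=C(C)C)C1=CC(=O)c2c(O)ccc(O)c2C1=O` gives 16600 nM, within the scatter of both compound 1 `CC(C)=CC[C@@H](OC[C@@H](C)O)C1=CC(=O)c2c(O)ccc(O)c2C1=O` at 14300 nM and compound 2 `CCC(CO[C@H](CC=C(C)C)C1=CC(=O)c2c(O)ccc(O)c2C1=O)OC(C)=O` at 25400 nM. The move to compound 4 `CC(C)=CC[C@@H](OCCO)C1=CC(=O)c2c(O)ccc(O)c2C1=O` is hydroxymethyl in place of 1-acetoxyethyl on a saturated chain carbon bound to an oxygen on a saturated carbon, with hydroxymethyl in place of 1-acetoxyethyl on a saturated chain carbon bound to an oxygen on a saturated carbon. Within the data shown here, two measured steps bear on it. The exchange of 1-hydroxyethyl for 1-acetoxyethyl gave a 1.2-fold higher number from compound 1 to compound 3 (0.06 log units; within the scatter), and hydrogen in place of methyl gave a 1.5-fold lower number from compound 2 to compound 3 (0.18 log units; within the scatter). Both stayed within the scatter, as did a 1.8-fold higher number from compound 1 to compound 2 (0.25 log units; within the scatter). No step beyond the scatter is therefore expected in this assay, and the estimated step is a 1.1-fold lower number from compound 3 to compound 4 (0.04 log units; within the scatter). For compound 4 the estimated value is 15000 nM, with an expected range of 7500 nM to 30000 nM.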

Compound 4, half-maximal inhibitory concentration: 9900 nM
The estimate for compound 4 lay 1.5-fold (0.18 log units) above the measured number; the range from low to high includes it.
By their numbers in this assay, from the lowest: compounds 4, 1, 3 and 2 (each within the scatter of the next, the first and the last beyond it).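

In this assay, among these compounds, hydroxymethyl in place of 1-acetoxypropyl gives the first step beyond the scatter at this position, a 2.6-fold lower number from compound 2 to compound 4 (0.41 log units; beyond the scatter), while hydroxymethyl in place of 1-acetoxyethyl stays within it, a 1.7-fold lower number from compound 3 to compound 4 (0.22 log units; within the scatter). Hydrogen in place of methyl on the saturated chain carbon also stays within it, a 1.4-fold lower number from compound 1 to compound 4 (0.16 log units; within the scatter). Loss of that methyl reads alike on two cores: the same change on two cores in this assay, a 1.5-fold lower number (0.18 log units; within the scatter) from compound 2 to compound 3 and a 1.4-fold lower number (0.16 log units; within the scatter) from compound 1 to compound 4, 1.1-fold (0.03 log units) apart, within the scatter of two such steps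

On these data alone, whether an amine or a carboxylic acid in place of hydroxymethyl would shift the number further remains open, as does the effect of a longer chain carrying a free hydroxyl.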